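This account rests on a few compounds, and the source may have more. Where it says the series, first, only, none or still open, it means among the compounds named here.

In a functional assay on HCT-116 cells (Homo sapiens) for antiproliferative activity, read by CellTiter-Glo, with a stated time of 72 h (on this read-out lower numbers stand for stronger inhibition and higher numbers for weaker inhibition), compound 2 `O=C(NO)c1ccc(/C=C/c2ccnc(-c3cccc(O)c3)c2)cc1` gives 1610 nM, the lower of the two actual numbers available. Compound 1 `O=C(NO)c1cccc(/C=C/c2ccnc(-c3cc(F)ccc3O)c2)c1` gives 3890 nM, a higher number and a gap beyond the usual scatter. Compound 3 `O=C(NO)c1ccc(/C=C/c2ccnc(-c3ccc(C(F)(F)F)cc3)c2)cc1` is reported only as a limit, > 10000 nM.

The next compound to be tested is compound 4 `Cc1ccc(-c2cc(/C=C/c3ccc(C(=O)NO)cc3)ccn2)c(F)c1`. It carries 2-fluoro-4-methylphenyl in place of the 3-hydroxyphenyl of compound 2, on an aromatic carbon next to the ring nitrogen: 2-fluoro-4-methylphenyl in place of 3-hydroxyphenyl on an aromatic carbon.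

Compounds 1 and 2 both carry a hydroxyl on this aryl ring, whereas compounds 3 and 4 do not. With so few compounds, this is only a weak guide, but it points towards weaker inhibition. A moderate move to a higher number is therefore expected, and the estimated step is a 2.8-fold higher number from compound 2 to compound 4 (0.45 log units; beyond the scatter). A result at the limit of the assay would not be surprising. For compound 4 the estimated value is 4500 nM, with an expected range from 1500 nM to 13000 nM.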

Compound 4, half-maximal inhibitory concentration: 800 nM
The estimate for compound 4 lay 5.6-fold (0.75 log units) above the measured number; the measured number lies below the stated range.
By their numbers in this assay, from the lowest: compounds 4 and 2 (each within the scatter of the next); then compound 1. At a limit, above all of these: compound 3.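

In this assay, going by these compounds alone, putting 2-fluoro-4-methylphenyl in place of 3-hydroxyphenyl on an aromatic carbon next to the ring nitrogen gives a 2.0-fold lower number from compound 2 to compound 4 (0.30 log units; within the scatter), so a hydroxyl on this aryl ring is not required for activity at the level of compound 2, and compound 4 goes against the link between a missing hydroxyl and weak inhibition that the earlier compounds hinted at. Compound 3, which also has no hydroxyl on this aryl ring, is reported only as a limit, > 10000 nM. The data shown do not explain why this exchange leaves the number within the scatter.

As far as these compounds go, the fluorine and the methyl enter together, so what each contributes alone remains open. Also open, from the compounds shown here alone, is how this position would respond to an aryl ring carrying an amine or a carboxylic acid.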